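This account rests on a few compounds, and the source may have more. Where it says the series, first, only, none or still open, it means among the compounds named here.

Working notes on the series. In a functional assay on HT-29 cells (Homo sapiens) for inhibition, with a stated time of 72 h (a lower number here means a stronger inhibitor, a higher number a weaker inhibitor), compound 1 `CCCn1ccc2cc(C(=O)c3cc(OC)c(OC)c(OC)c3)ccc21` gives 1800 nM and compound 2 `COc1cc(C(=O)c2ccc3c(ccn3C(C)C)c2)cc(OC)c1OC` gives 1200 nM as its reading, so compound 2 stands level with compound 1 within the scatter. For the measured compounds named here, the one measured step is a 1.5-fold lower number from compound 1 to compound 2 (0.18 log units; within the scatter) and it bears only partly on the change at hand.

Compound 3 `COc1cc(C(=O)c2ccc3c(ccn3CCC(=O)O)c2)cc(OC)c1OC` has 2-carboxyethyl in place of isopropyl on an aromatic nitrogen, with the change counted as 2-carboxyethyl in place of isopropyl on an aromatic nitrogen against compound 2. The same nitrogen is the place varied between compound 1 and compound 2, yet neither of them carries anything like the entering group, so the data hold no measured size for this exchange. In this assay a shift to a higher number, meaning a weaker inhibitor, is expected as a judgement, beyond the scatter but loosely bounded. The expected shift is a 5.0-fold higher number from compound 2 to compound 3 (0.70 log units; beyond the scatter) on this estimate. For compound 3 the estimated half-maximal inhibitory concentration is 6000 nM within an expected range from 1500 nM to 25000 nM for repeat measurements.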

Compound 3, half-maximal inhibitory concentration: > 10000 nM
Compound 3: no number, only a limit (the forecaster's own chance of this, stated with the estimate: 25%); middle value at least 1.6-fold (0.22 log units) away from the limit.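

The aromatic nitrogen had shown no shift beyond the scatter between its two earlier alkyl groups, but it now shows one: in this assay, the exchange of isopropyl for 2-carboxyethyl gives an at least 8.3-fold higher number from compound 2 to compound 3 (0.92 log units; beyond the scatter). The comparison with the propyl compound isolates the end of the chain, where carboxy in place of methyl on a saturated chain carbon, two bonds along the chain from an aromatic nitrogen, gives an at least 5.5-fold higher number from compound 1 to compound 3 (0.74 log units; beyond the scatter), so a change at that chain end is enough to move the reading beyond the scatter. Both steps give only a minimum size, as compound 3 carries a limit of the assay and not a number: the limit of > 10000 nM in this assay, at which 1 of the 3 values shown sits.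

From the compounds shown here alone, the true size of the shift remains open, as does whether it requires the free carboxylic acid or would also appear with other groups at the chain end. A methyl ester, a primary amide, a primary amine or a hydroxyl at that chain end, or a carboxylic acid on a longer chain, would bear on this question.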